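This account rests on a few compounds, and the source may have more. Where it says the series, first, only, none or still open, it means among the compounds named here.

Working notes on the oxime-ether acid series built on the core of compound 1 `C/C(=N\OC(c1ccc(OCc2ccc3cc(F)ccc3n2)cc1)C1CCCCC1)C(=O)O`, where only the aromatic group on a saturated chain carbon bound to an oxygen on an aromatic ring is varied. In a functional assay for inhibition of Polyunsaturated fatty acid 5-lipoxygenase (Homo sapiens) (on this read-out higher numbers stand for weaker inhibition and lower numbers for stronger inhibition), compound 1 gives 20 nM. Compound 2 `C/C(=N\OC(c1ccc(OCc2cscn2)cc1)C1CCCCC1)C(=O)O` gives 360 nM in this assay, and compound 3 `C/C(=N\OC(c1ccc(OCc2nc3ccccc3s2)cc1)C1CCCCC1)C(=O)O` gives 60 nM. Compound 3 therefore holds the second highest number of the three measured: compound 1 sits nearest, a 3.0-fold higher number from compound 1 to compound 3 (0.48 log units; beyond the scatter), while compound 2 lies furthest, a 6.0-fold lower number from compound 2 to compound 3 (0.78 log units; beyond the scatter). Across the two ends of the set, an 18-fold higher number from compound 1 to compound 2 (1.26 log units; beyond the scatter).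

Compound 4 `C/C(=N\OC(c1ccc(OCc2nc3ccccc3n2C)cc1)C1CCCCC1)C(=O)O` follows from compound 3 by 1-methyl-1H-benzimidazol-2-yl in place of 1,3-benzothiazol-2-yl on a saturated chain carbon bound to an oxygen on an aromatic ring. Both groups are fused bicycles at the same place, so the step from compound 2 to compound 3, where a fused carbon ring enters, and the step from compound 1 to compound 3, where one bicycle replaces another, are the bearing comparisons; both moved the number beyond the scatter but not greatly. For the measured compounds named here, no measured step swaps a ring sulfur for a methylated ring nitrogen, so the direction is open. For compound 4 the expectation in this assay is a small rise, a 1.5-fold higher number from compound 3 to compound 4 (0.18 log units; within the scatter), estimated at 90 nM within a range of 30 nM to 300 nM.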

Compound 4, half-maximal inhibitory concentration: 820 nM
Compound 4: the middle estimate sits 9.1-fold (0.96 log units) below what was measured; measured number outside the range, above it.
By their numbers in this assay, from the lowest: compound 1; then compound 3; then compound 2; then compound 4.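

Before this result, the fused bicycles of compound 1 and compound 3 both gave lower numbers than the single ring of compound 2, but compound 4 goes against that pattern in this assay (a 2.3-fold higher number from compound 2 to compound 4 (0.36 log units; beyond the scatter)), so a fused bicycle at this place is not enough on its own to give a low number. The position also separates two fused bicycles with the same ring types and the same hydrogen-bond donor and acceptor counts (a 14-fold higher number from compound 3 to compound 4 (1.14 log units; beyond the scatter)), and compound 4 lies far from the 6-fluoroquinolin-2-yl compound as well (a 41-fold higher number from compound 1 to compound 4 (1.61 log units; beyond the scatter)), so those shared counts do not settle the outcome here. No measurement at hand bears on the cause of this rise.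

The change from 1,3-benzothiazol-2-yl to 1-methyl-1H-benzimidazol-2-yl alters the ring atoms and adds a methyl group in one step, so the compounds shown cannot apportion the rise between the two. The unmethylated 1H-benzimidazol-2-yl group and the 1,3-benzoxazol-2-yl group at this place would be the direct comparisons for separating them.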